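The source may report more compounds than this note shows. Statements on the series, on what has been measured and on what is new or still open speak of the compounds shown alone.

Measured compounds:
- compound 1, `CCCC(C)n1c(CC)nc2c(-c3ccc(C(F)(F)F)cc3Cl)ccnc21`: 1.1 nM
- compound 2, `CCc1nc2c(-c3ccc(Cl)cc3Cl)ccnc2n1[C@H](C)C1CC1`: 0.6 nM

In an assay for binding affinity to Corticotropin releasing factor receptor (Rattus norvegicus) (on this read-out lower numbers stand for stronger inhibition and higher numbers for weaker inhibition), compound 1 gives 1.1 nM and compound 2 gives 0.6 nM. Among the measured compounds shown here, the two numbers lie within the usual scatter of each other, so neither compound can be called the more potent on this evidence, and since the two structures differ in more than one place no single step between them can be drawn.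

Compound 3, `CCc1nc2c(-c3ccc(Cl)cc3Cl)ccnc2n1C(C)CC`, is the next compound in this series and has not been measured. It differs from compound 2 in one place: sec-butyl in place of 1-cyclopropylethyl on an aromatic nitrogen. Both groups are small saturated carbon chains on the same ring nitrogen, and both compounds carry the same ethyl group and the same dichlorophenyl ring on the shared core. Compound 1 shows that a plain chain on that nitrogen is compatible with a low number in this assay, though its aryl ring is different.

The step from compound 2 to compound 3 is therefore expected to be small, a 1.7-fold higher number from compound 2 to compound 3 (0.22 log units; within the scatter), with no clear direction beyond the scatter. Compound 3 is estimated at 1 nM, within a range of 0.4 nM to 3 nM.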

Compound 3, inhibition constant: 1.3 nM
Beside the measured number, compound 3's estimate is 1.3-fold (0.11 log units) below it, within the range that was stated.
By their numbers in this assay, from the lowest: compounds 2, 1 and 3 (each within the scatter of the next, the first and the last beyond it).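

In this assay, exchanging 1-cyclopropylethyl for sec-butyl on the aromatic nitrogen, with the ethyl group and the dichlorophenyl ring of the shared core unchanged, gives a 2.2-fold higher number from compound 2 to compound 3 (0.34 log units; beyond the scatter). Among the compounds shown here, this is the first comparison that isolates this position, and it shows that the read-out responds, modestly, to a change confined to this nitrogen substituent, even though neither group carries a hydrogen-bond donor or acceptor. Nothing available explains the difference between the two groups.

The single step removes the three-membered ring, changes the heavy-atom count and loses the defined stereocentre all at once, so the compounds shown cannot tell which of these differences accounts for the step. Also open, on these data alone, is how the read-out would respond at this nitrogen to a cyclopropylmethyl group, to a longer chain such as 1-cyclobutylethyl, or to a chain bearing a methoxy group, and whether the same step would appear with the trifluoromethyl-bearing aryl ring of compound 1.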